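This account rests on a few compounds, and the source may have more. Where it says the series, first, only, none or still open, it means among the compounds named here.

Notes on the series. In an ADME assay on MT4 cells (Homo sapiens) for cytotoxicity, read by MTT assay, with a stated time of 96 h (on this read-out higher numbers stand for lower toxicity in this test and lower numbers for higher toxicity in this test), compound 1 (`Fc1ccc(F)c(/N=N/Nc2ccccc2)c1`) gives 100000 nM. Going by the values given here, compound 2 (`CN(C)CCCN(/N=N/c1cc(F)ccc1F)c1ccccc1`) gives 13000 nM, the lower of the two numbers so far. The next structure is compound 3 (`CN(C)CCCN(/N=N/c1cc(F)ccc1F)c1cccc(C(F)(F)F)c1`), which keeps the 3-(dimethylamino)propyl chain of compound 2 and carries one change: trifluoromethyl in place of hydrogen on an aromatic carbon. Among the compounds with values here, the only measured step is a 7.7-fold lower number from compound 1 to compound 2 (0.89 log units; beyond the scatter), a modest one that came with 3-(dimethylamino)propyl in place of hydrogen on a nitrogen. That step lies at another place in the structure, so it gives only a rough scale. Within the data shown here, no measured step covers trifluoromethyl in place of hydrogen on an aromatic carbon. In this assay, the expected move is a 1.9-fold lower number from compound 2 to compound 3 (0.27 log units; within the scatter), a small estimated shift towards a lower number that is smaller than the measured step. For compound 3 the estimated value is 7000 nM, with an expected range from 2500 nM to 20000 nM.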

Compound 3, half-maximal cytotoxic concentration: 16000 nM
Estimate against measurement, compound 3: 2.3-fold (0.36 log units) below; measured number inside the range.
By their numbers in this assay, from the lowest: compounds 2 and 3 (each within the scatter of the next); then compound 1.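

Trifluoromethyl in place of hydrogen on an aromatic carbon, meta to a large group, is the first change on this six-membered aromatic ring that can be read in this assay: it gives a 1.2-fold higher number from compound 2 to compound 3 (0.09 log units; within the scatter), so compound 3 and compound 2 cannot be told apart. With the 3-(dimethylamino)propyl chain kept, this substituent of 4 heavy atoms leaves the read-out within the scatter, whereas the change on the nitrogen gave a 7.7-fold lower number from compound 1 to compound 2 (0.89 log units; beyond the scatter). No measurement bears on why the number holds at this position.

Open, going by these compounds, is whether a smaller substituent at this place, such as a chlorine atom or a methoxy group, or a carboxylic acid, would also leave the number within the scatter. Also open, on these data alone, is whether a longer amine chain on the nitrogen would shift it, and whether trifluoromethyl behaves the same way without the chain.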